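Silyl ether cyclopentenones: cytotoxicity after an aryl swap

The source may hold more compounds than are shown below. What is called first, only, known or untested is meant among the compounds shown, and "the series" means these compounds.

Among the measured compounds shown here, in an ADME assay on HEK293 cells (Homo sapiens) for cytotoxicity, read by MTT assay, with a stated time of 72 h (a lower number here means a stronger inhibitor, a higher number a weaker inhibitor), compound 2 `COc1ccc(OC)c(C2=C(c3cc(OC)c(OC)c(OC)c3)C(=O)CC2O[SiH2]C(C)(C)C)c1` is the only member of the series that gives a number, at 9.5 ug/mL. Compound 1 `COc1ccc(C2=C(c3cc(OC)c(OC)c(OC)c3)C(=O)C(O[SiH2]C(C)(C)C)C2)cc1OC(C)C` gives a limit of the assay, > 100 ug/mL. Compound 3 `COc1ccc(OC)c(C2=C(c3cc(OC)c(OC)c(OC)c3)C(=O)CC2O)c1` keeps the shared core but carries a free hydroxyl; compound 3 likewise gives a limit, > 100 ug/mL. The one measured step, an at least 10-fold higher number from compound 2 to compound 3 (1.02 log units; beyond the scatter), ties the number of compound 2 to the group of 5 heavy atoms on the oxygen on a saturated carbon, as shown by the limit of > 100 ug/mL in this assay, at which 2 of the 3 values shown sit.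

Compound 4 `COc1ccc(C2=C(c3cc(OC)c(OC)c(OC)c3)C(=O)CC2O[SiH2]C(C)(C)C)cc1` differs from compound 2 in the aryl group: 4-methoxyphenyl in place of 2,5-dimethoxyphenyl on a double-bonded ring carbon The silyl ether is kept. For the measured compounds named here, no measured step touches this ring, so the step from compound 2 to compound 3 bears on it only indirectly, by showing that the group retained in compound 4 is the one that separates a number from a limit. Compound 1 and compound 2 differ in more than one place, so their values alone do not isolate the aryl change. For compound 4 a step of a 2.1-fold higher number from compound 2 to compound 4 (0.32 log units; beyond the scatter) is therefore expected, with the number likely staying short of the limit. The estimated value for compound 4 is 20 ug/mL, within 6 ug/mL to 80 ug/mL.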

Compound 4, half-maximal inhibitory concentration: > 100 ug/mL
Compound 4: only a limit was reported; the forecaster's own chance of this, stated with the estimate: 35%; at least 5.0-fold (0.69 log units) between middle value and limit.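

In this assay the change to 4-methoxyphenyl in place of 2,5-dimethoxyphenyl on a double-bonded ring carbon gives an at least 10-fold higher number from compound 2 to compound 4 (1.02 log units; beyond the scatter) with the silyl ether kept, so the silyl ether alone does not secure a number and the aryl group at this position also counts. Within the compounds shown, the number of compound 2 now depends on two places, since an at least 10-fold higher number from compound 2 to compound 3 (1.02 log units; beyond the scatter) had tied it only to the silyl ether, and compound 2 remains the only compound with a number. The size of the new step is a floor and not a measured gap, because the value of compound 4 is a limit of the assay, as are most values in the series: the limit of > 100 ug/mL in this assay, at which 3 of the 4 values shown sit.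

Open, on these data alone, is which of the two methoxy groups of 2,5-dimethoxyphenyl the number depends on, and whether a dimethylamino group or a carboxylic acid on this aryl ring would give a number in this assay. Also open, as far as these compounds go, is how far the true value of compound 4 lies from its limit.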